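Ester to Acid on a Shared Core: Orexin Binding

The compounds below may be only part of what the source reports. "The series", "measured", "known", "first", "only" and "open" are said of these compounds alone.

Of the compounds shown here, three built on one shared core have been measured in an assay on cells for displacement of a labelled ligand from Orexin receptor type 2 (Homo sapiens), read by scintillation counting, with stated times of 10 min and 90 min, tested at 10 uM; a higher number here means more inhibition at the concentration tested (going by the name of the read-out), a lower number less inhibition. Compound 1 `COC(=O)c1ccc2ccc(C(=O)c3ccccc3)c-2cc1` gives 28.9% in that measurement. Compound 2 `O=C(O)c1ccc2ccc(C(=O)c3ccccc3)c-2cc1` carries hydrogen in place of methyl on an oxygen next to a carbonyl group and gives 32.9%, so the step of a number 4 percentage points higher from compound 1 to compound 2 (within the scatter) stays inside the scatter. Compound 3 `COC(=O)c1ccc2ccc(C=O)c-2cc1` carries hydrogen in place of phenyl on a carbonyl carbon and gives 37.2%, and the step of a number 8.3 percentage points higher from compound 1 to compound 3 (within the scatter) likewise stays inside the scatter. Going by the values given here, compound 3 therefore holds the largest of the three numbers, yet every gap among them lies within the usual scatter, so no compound stands apart.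

Compound 4 `O=Cc1ccc2ccc(C(=O)O)ccc1-2` has not been measured. It differs from compound 3 by hydrogen in place of methyl on an oxygen next to a carbonyl group, the methoxycarbonyl becoming carboxy. Among the compounds with values here, the only measured step of the same kind is a number 4 percentage points higher from compound 1 to compound 2 (within the scatter) and it lay within the scatter. Compound 4 is therefore expected to give about 40% in this assay, with a range from 26% up to 54% for that measurement. The expected step is a number 2.8 percentage points higher from compound 3 to compound 4 (within the scatter), which is nothing beyond the scatter in either direction.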

Compound 4, a percentage reported as inhibition, at one concentration (the size of the read-out at that concentration, not a potency): 44.1%
For compound 4 the middle estimate is 4.1 percentage points below the measured one, and the stated range covers the measured number.
By their numbers in this assay, from the lowest: compounds 1, 2, 3 and 4 (each within the scatter of the next, the first and the last beyond it).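

Replacing methoxycarbonyl with carboxy gives, in this assay, a number 6.9 percentage points higher from compound 3 to compound 4 (within the scatter), and this change now reads alike on two cores: the same change on two cores in this assay, a number 4 percentage points higher (within the scatter) from compound 1 to compound 2 and a number 6.9 percentage points higher (within the scatter) from compound 3 to compound 4, 2.9 percentage points apart, within the scatter of two such steps. Hydrogen in place of phenyl on a carbonyl carbon gives a number 11.2 percentage points higher from compound 2 to compound 4 (beyond the scatter), the first step in this set to pass beyond the scatter, though only modestly, and it too agrees with the same change on the other core: the same change on two cores in this assay, a number 8.3 percentage points higher (within the scatter) from compound 1 to compound 3 and a number 11.2 percentage points higher (beyond the scatter) from compound 2 to compound 4, 2.9 percentage points apart, within the scatter of two such steps. Across these four compounds, each change therefore looks much the same whichever group sits at the other place.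

The compounds shown leave open what other groups would do at these two places, such as an amide in place of the carboxy or a longer chain in place of the hydrogen on the carbonyl carbon. Each number also comes from one concentration, so none of them gives a potency.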